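A few compounds are considered here, and "the series" means these few. Any claim that something is new, unique, unknown or untested is made for them only; others in the source may bear on it.

Compound 1 `CCc1ccc(Nc2cc(NC(=O)Nc3cc(OC)cc(OC)c3)ncn2)cc1` gives 32.7% in a functional assay on NCI-H1581 cells (Homo sapiens) for inhibition, read by MTT assay, with a stated time of 48 h, tested at 10 uM (a lower number here means less inhibition, a higher number more inhibition at the concentration tested (going by the name of the read-out)), the lower of the two numbers in hand. For the measured compounds named here, compound 2 `COc1cc(Nc2cc(NC(=O)Nc3c(Cl)cccc3Cl)ncn2)cc(OC)c1` gives 68%, and since it differs from compound 1 in more than one place, that gap sets no single step. Compound 3 `COc1cc(NC(=O)Nc2cc(Nc3cc(C)cc(F)c3)ncn2)cc(OC)c1` carries 3-fluoro-5-methylphenyl in place of 4-ethylphenyl on a nitrogen on an aromatic ring. Going by the values given here, no measured step of this kind exists, so the expectation rests on compound 1 alone: the step is estimated as a number 5.3 percentage points higher from compound 1 to compound 3 (within the scatter), expected to stay within the scatter, with no clear direction. Compound 3 is therefore estimated at 38%, in a range from 18% to 60%.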

Compound 3, a percentage reported as inhibition, at one concentration (the size of the read-out at that concentration, not a potency): 28.3%
Estimate against measurement, compound 3: 9.7 percentage points above, and the stated range covers the measured number.
By their numbers in this assay, from the lowest: compounds 3 and 1 (each within the scatter of the next); then compound 2.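

For the compounds shown here, at the nitrogen on an aromatic ring, 3-fluoro-5-methylphenyl in place of 4-ethylphenyl gives a number 4.4 percentage points lower from compound 1 to compound 3 (within the scatter) in this assay, the only single-place step in hand. Between these two phenyl groups of equal heavy-atom count, the number at this place does not move beyond the scatter. Nothing measured here bears on this result.

Still open, on these data alone, is whether a different group at this place, such as an amine or a carboxylic acid on the phenyl ring, would move the number beyond the scatter. As far as these compounds go, a longer chain in place of the ethyl group is equally open.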